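Benzoyl in place of the oxime-bearing group: compound 3 to compound 4

The source may report more compounds than this note shows. Statements on the series, on what has been measured and on what is new or still open speak of the compounds shown alone.

Three compounds already have a number in a functional assay on the whole organism (strain albino) for inhibition, with Rattus norvegicus as the target, read by paw edema, with a stated time of 2 h, at a dose of 0.28 mmol/kg by the oral route; on this read-out lower numbers stand for less inhibition and higher numbers for more inhibition at the one dose given (going by the name of the read-out):
Compound 1, `COc1ccc(-c2nnc(SCC(=O)c3ccccc3)n2-c2ccccc2)cc1OC`, gives 57%.
Compound 2, `COc1ccc(-c2nnc(SC/C(=N/O)c3ccccc3)n2-c2ccccc2)cc1OC`, gives 61%.
Compound 3, `COc1cc(-c2nnc(SC/C(=N/O)c3ccccc3)n2-c2ccccc2)cc(OC)c1OC`, gives 61%.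

Compound 3 stands level with compound 2 at the digits shown, and the two together hold the highest numbers of the three. The measured steps are a number 4 percentage points higher from compound 1 to compound 2 (within the scatter) and then no change at the digits printed from compound 2 to compound 3 (within the scatter), so nothing among them reaches beyond the scatter.

Compound 4, `COc1cc(-c2nnc(SCC(=O)c3ccccc3)n2-c2ccccc2)cc(OC)c1OC`, is still to be measured. Its change from compound 3 is a group of 8 heavy atoms (7 carbon, 1 oxygen; one six-membered aromatic ring of carbon only) in place of a group of 9 heavy atoms (7 carbon, 1 nitrogen, 1 oxygen; one six-membered aromatic ring of carbon only), on a saturated chain carbon bound to a sulfur. Within the data shown here, one measured step bears on it directly: the same exchange in the opposite direction, on the core that carries one methoxy group fewer, gave a number 4 percentage points higher from compound 1 to compound 2 (within the scatter). The added methoxy group itself left the number untouched, as no change at the digits printed from compound 2 to compound 3 (within the scatter) shows. Compound 4 is therefore expected to come out a shade below compound 3, a step of a number 4 percentage points lower from compound 3 to compound 4 (within the scatter), still within the scatter. The estimate for compound 4 in this assay is 57%, with a range from 48% to 66%.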

Compound 4, a percentage reported as inhibition, in the whole organism at one dose (the size of the read-out at that dose, not a potency): 51%
Compound 4: the middle estimate sits 6 percentage points above what was measured; the measured number falls inside the stated range.
By their numbers in this assay, from the lowest: compounds 4, 1, 2 and 3 (each within the scatter of the next).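

In this assay, the exchange of the oxime-bearing group for benzoyl, on a saturated chain carbon bound to a sulfur, can now be read on a second core, where it gives a number 10 percentage points lower from compound 3 to compound 4 (within the scatter), and the two readings of this exchange agree: the same change on two cores in this assay, a number 4 percentage points higher (within the scatter) from compound 1 to compound 2 and a number 10 percentage points higher (within the scatter) from compound 4 to compound 3, 6 percentage points apart, within the scatter of two such steps. Methoxy in place of hydrogen on an aromatic carbon can also now be read twice, the new reading being a number 6 percentage points lower from compound 1 to compound 4 (within the scatter), and these two readings agree as well: the same change on two cores in this assay, no change at the digits printed (within the scatter) from compound 2 to compound 3 and a number 6 percentage points lower (within the scatter) from compound 1 to compound 4, 6 percentage points apart, within the scatter of two such steps. Neither change therefore stands clear of the scatter on either core, so the four compounds support no claim that either the oxime-bearing group or the added methoxy group alters the number.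

Going by these compounds, it remains open whether an amine or a carboxylic acid on this saturated chain carbon, in place of the benzoyl or oxime-bearing group, would carry the number beyond the scatter. All the numbers shown come from a single dose and a single time, so how these compounds compare in potency also remains open.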